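Free fraction after replacing cyclopentyl with butyl

A few compounds are considered here, and "the series" means these few. Any claim that something is new, unique, unknown or untested is made for them only; others in the source may bear on it.

In an ADME assay on the whole organism (plasma, Rattus norvegicus, strain Sprague-Dawley) for protein binding, read by LC-MS, with a stated time of 24 h (on this read-out lower numbers stand for a smaller free fraction and higher numbers for a larger free fraction), compound 1 `CN(C(=O)OCc1c(-c2ccc(O[C@H]3CCC[C@H](C(=O)O)C3)cc2)nnn1C)C1CCCC1` gives 0.027 and compound 2 `Cc1noc(-c2ccc(O[C@H]3CCC[C@H](C(=O)O)C3)cc2)c1CNC(=O)OCCC(C)(C)C` gives 0.001 while compound 3 `Cc1noc(-c2ccc(O[C@H]3CCC[C@H](C(=O)O)C3)cn2)c1COC(=O)N(C)C1CCCC1` gives 0.009 and so stands second highest of the three. Its gaps to compound 1 and compound 2 both lie beyond the usual scatter. Compound 4 `CCCCN(C)C(=O)OCc1c(C)noc1-c1ccc(O[C@H]2CCC[C@H](C(=O)O)C2)cn1` has not yet been measured. It carries butyl in place of cyclopentyl on an amide-type nitrogen, a difference counted as butyl in place of cyclopentyl on an amide-type nitrogen in its structure. Among the measured compounds shown here, no measured pair shows this same change, so the evidence is indirect. The expected result in this assay is a 1.1-fold lower number from compound 3 to compound 4 (0.05 log units; within the scatter) as an estimated small step within the scatter, with no firm direction. Compound 4 is estimated at 0.008 with a range from 0.004 to 0.016 expected on measurement.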

Compound 4, unbound fraction: 0.012
Beside the measured number, compound 4's estimate is 1.5-fold (0.18 log units) below it; the range from low to high includes it.
By their numbers in this assay, from the lowest: compound 2; then compounds 3 and 4 (each within the scatter of the next); then compound 1.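

In this assay, the first pair differing in one place gives a 1.3-fold higher number from compound 3 to compound 4 (0.12 log units; within the scatter), so on this amide-type nitrogen the open butyl chain and the cyclopentyl ring cannot be told apart by free fraction. The earlier compounds shown here, which differ in more than one place, could not show this. No evidence available here accounts for the result. The compounds shown leave open how a longer chain or an amine on this nitrogen would read, and whether butyl and cyclopentyl also read alike on the core of compound 1.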